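Naphthalen-1-yl in place of pyridin-3-yl: compound 4 expected

The compounds below may be only part of what the source reports. "The series", "measured", "known", "first", "only" and "open" are said of these compounds alone.

The measured compounds and their values:
compound 1 `Nc1scc(CN2CCN(c3ccc(Cl)cc3Cl)CC2)c1C(=O)c1ccc(Cl)cc1` — 0%
compound 2 `Nc1scc(CN2CCN(c3ccccc3C(F)(F)F)CC2)c1C(=O)c1ccc(Cl)cc1` — 0%
compound 3 `Nc1scc(CN2CCN(c3cccnc3)CC2)c1C(=O)c1ccc(Cl)cc1` — 0%

In an assay on CHO cells for displacement of a labelled ligand from adenosine receptor A3 (Homo sapiens), read by scintillation counting, with a stated time of 120 min, tested at 10 uM (a lower number here means less inhibition, a higher number more inhibition at the concentration tested (going by the name of the read-out)), compound 1 gives 0%, compound 2 gives 0% and compound 3 gives 0%. Compound 3 therefore stands level with compounds 1 and 2; the differences among the three lie within the scatter. The group on the amine nitrogen in the ring has been varied across these three compounds without any effect on the read-out: no change at the digits printed from compound 1 to compound 2 (within the scatter), no change at the digits printed from compound 1 to compound 3 (within the scatter) and no change at the digits printed from compound 2 to compound 3 (within the scatter).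

Compound 4 `Nc1scc(CN2CCN(c3cccc4ccccc34)CC2)c1C(=O)c1ccc(Cl)cc1` takes this variation one step further. naphthalen-1-yl in place of pyridin-3-yl on an amine nitrogen in a ring

All three measured steps at this position, which bear directly on the change from compound 3 to compound 4, showed no movement beyond the scatter. Going by the values given here, on that basis no step in this assay beyond the scatter is expected for compound 4, and the expected step is no change at the digits printed from compound 3 to compound 4 (within the scatter). The estimate for compound 4 in this assay is 0%, with a range from -10% to 15%.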

Compound 4, a percentage reported as inhibition, at one concentration (the size of the read-out at that concentration, not a potency): 0%
The estimate for compound 4 equals the measured number at the digits printed, and the stated range covers the measured number.
By their numbers in this assay, from the lowest: compounds 1, 2, 3 and 4 (each within the scatter of the next).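

In this assay the move to naphthalen-1-yl, a group of 10 carbon atoms in two aromatic rings, gives no change at the digits printed from compound 3 to compound 4 (within the scatter) and so brings a larger aryl group onto the amine nitrogen in a ring, without the ring nitrogen and hydrogen-bond acceptor of pyridin-3-yl, and still leaves the read-out unmoved. The comparisons with the two substituted phenyl compounds agree, with no change at the digits printed from compound 2 to compound 4 (within the scatter) and also no change at the digits printed from compound 1 to compound 4 (within the scatter), so the insensitivity seen among single aromatic rings at this position now extends to a two-ring aromatic group. No measurement shown here accounts for this lack of response, and the four compounds are not separated by this read-out at the concentration tested.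

Going by these compounds, all four compounds carry an aromatic group on this nitrogen, so it remains open whether a benzyl group, a longer alkyl chain or an aryl group bearing a carboxylic acid would give any inhibition in this assay at all. On these data alone, it is also open whether changing the shared core elsewhere, for instance replacing the free amine with an amide or the chlorine on the aryl ketone with a methoxy group, would give a read-out on which this position could be compared.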